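The source may hold more compounds than are shown below. What is called first, only, known or untested is meant among the compounds shown, and "the series" means these compounds.

Working notes on the series. Three compounds share one core and differ only in the group on the amide-type nitrogen. Compound 1 `CCN(C(=O)C1CCN(S(=O)(=O)c2ccc3cn[nH]c3c2)CC1)[C@H](C)c1ccccc1` gives 87% in a functional assay on CHO cells for positive allosteric modulation of muscarinic acetylcholine receptor M5 (Homo sapiens), read by calcium flux; on this read-out lower numbers stand for smaller maximal responses and higher numbers for larger maximal responses. Compound 2 `CCN(Cc1cccc(F)c1)C(=O)C1CCN(S(=O)(=O)c2ccc3cn[nH]c3c2)CC1` gives 89% in this assay, and compound 3 `CCN(Cc1cccc(C)c1)C(=O)C1CCN(S(=O)(=O)c2ccc3cn[nH]c3c2)CC1` gives 78% in this assay. Among these three numbers compound 3 stands lowest: the step of a number 9 percentage points lower from compound 1 to compound 3 (within the scatter) stays within the scatter, while the step of a number 11 percentage points lower from compound 2 to compound 3 (beyond the scatter) lies just beyond it.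

Compound 4 `CCN(Cc1ccccc1Cl)C(=O)C1CCN(S(=O)(=O)c2ccc3cn[nH]c3c2)CC1` is not yet measured. The change from compound 3 to compound 4 is 2-chlorophenyl in place of 3-methylphenyl on a saturated chain carbon bound to an amide-type nitrogen. The measured steps that touch compound 3 are a number 9 percentage points lower from compound 1 to compound 3 (within the scatter) and a number 11 percentage points lower from compound 2 to compound 3 (beyond the scatter); both are small, and the swap of methyl for fluoro on an aromatic carbon gave only a modest move. Going by the values given here, no measured step covers a chlorine on this ring, and none covers the position the 2-chlorophenyl takes, so the direction rests on weak ground. Since compound 3 holds the lowest number and all three numbers sit close, compound 4 is expected to land near the others, with a step of a number 6 percentage points higher from compound 3 to compound 4 (within the scatter) that is expected to stay within the scatter. The estimate for compound 4 in this assay is 84%, with a range from 71% to 97%.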

Compound 4, largest response reached (reported as percent of maximum), in percent of the reference or control that the assay uses: 93%
Estimate against measurement, compound 4: 9 percentage points below; the range from low to high includes it.
By their numbers in this assay, from the lowest: compounds 3, 1, 2 and 4 (each within the scatter of the next, the first and the last beyond it).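

In this assay, the 2-chlorophenyl in place of the 3-methylphenyl gives a number 15 percentage points higher from compound 3 to compound 4 (beyond the scatter), which changes both the substituent and its place on the ring in one step. Compound 3 now has a step beyond the scatter to two compounds, the other being a number 11 percentage points lower from compound 2 to compound 3 (beyond the scatter), although a number 9 percentage points lower from compound 1 to compound 3 (within the scatter) keeps it within the scatter of compound 1, while a number 4 percentage points higher from compound 2 to compound 4 (within the scatter) and a number 6 percentage points higher from compound 1 to compound 4 (within the scatter) show that the 2-chlorobenzyl, 3-fluorobenzyl and 1-phenylethyl groups cannot be told apart on this read-out. Nothing available here accounts for any of these steps.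

The compounds shown leave open whether the chlorine or its place on the ring carries the step from the 3-methylphenyl, a question that 3-chlorophenyl and 2-methylphenyl groups would separate. They also leave open how far this position tolerates a ring carrying an amine or a carboxylic acid, and whether a propyl chain in place of the ethyl on the amide-type nitrogen would keep the response.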